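A few compounds are considered here, and "the series" means these few. Any claim that something is new, unique, unknown or untested is made for them only; others in the source may bear on it.

Measured in a functional assay (Platelet, plasma) for inhibition, with Homo sapiens as the target; a lower number here means a stronger inhibitor, a higher number a weaker inhibitor:
compound 1 `CC1OC(=O)c2cc(C#N)c(N3CC(C(=O)NS(=O)(=O)Cc4ccccc4)C3)nc21`: > 300000 nM, a limit of the assay, not a number
compound 2 `N#Cc1cc2c(nc1N1CC(C(=O)NS(=O)(=O)Cc3ccccc3)C1)COC2=O`: > 300000 nM, likewise a limit
compound 3 `CC1(C(=O)NS(=O)(=O)Cc2ccc(Cl)cc2)CCN(c2nc3c(cc2C#N)C(=O)OC3)CC1`: 3010 nM

Compound 1 differs from compound 2 by hydrogen in place of methyl on a saturated ring carbon; the step that the two limits leave unreadable from compound 1 to compound 2 cannot be read because of the limit of > 300000 nM in this assay, at which 2 of the 3 values shown sit. Among the compounds with values here, compound 3 is the only one with a number; the difference between its core and the core of compound 1 is not broken down here. Compound 4 `N#Cc1cc2c(nc1N1CCC(C(=O)NS(=O)(=O)Cc3ccc(Cl)cc3)CC1)COC2=O` is not yet measured and differs from compound 3 by hydrogen in place of methyl on a saturated ring carbon. This is the same kind of change as from compound 1 to compound 2, not the same: there the methyl sat on a five-membered non-aromatic ring with one oxygen, part of a fused or bridged system of two rings, next to the ring oxygen; here it sits on a six-membered non-aromatic ring with one nitrogen, three ring bonds from the ring nitrogen. Because a step that the two limits leave unreadable from compound 1 to compound 2 gives no readable size, the step of a 1.3-fold higher number from compound 3 to compound 4 (0.12 log units; within the scatter) is expected to stay within scatter. Compound 4 is estimated at 4000 nM in this assay, between 1000 nM and 20000 nM.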

Compound 4, half-maximal inhibitory concentration: 4420 nM
The estimate for compound 4 lay 1.1-fold (0.04 log units) below the measured number; low and high end bracket the measured number.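

In this assay, hydrogen in place of methyl on a saturated ring carbon, three ring bonds from the ring nitrogen, gives a 1.5-fold higher number from compound 3 to compound 4 (0.17 log units; within the scatter). The same kind of change on the other core, from compound 1 to compound 2, cannot be read, because both compounds sit at a limit of the assay and not at a number: the limit of > 300000 nM in this assay, at which 2 of the 4 values shown sit. The result therefore holds for the core of compound 3 alone and does not show that the change carries over to the core of compound 1 with the same size.

Open, going by these compounds, is what an amine, a carboxylic acid or a longer chain such as ethyl would give on this saturated ring carbon. Also open, on these data alone, is whether any change on the core of compound 1 would bring a readable number.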